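The compounds below may be only part of what the source reports. "The series", "measured", "known", "first", "only" and "open" are said of these compounds alone.

Notes on the series. In a functional assay on HCT-116 cells (Homo sapiens) for cytotoxicity, read by MTT assay, with a stated time of 24 h (a lower number here means a stronger inhibitor, a higher number a weaker inhibitor), compound 3 `COc1ccc(/C=C\C(=O)O)c(OCc2cn(-c3ccccc3)nn2)c1CC=C(C)C` gives 26000 nM. Compound 1 `COc1ccccc1-n1cc(COc2c(/C=C\C(=O)O)ccc(OC)c2CC=C(C)C)nn1` gives 32200 nM and compound 2 `COc1ccc(/C=C\C(=O)O)c(OCc2cn(-c3ccc(NC(=O)c4ccccc4)cc3)nn2)c1CC=C(C)C` gives 16400 nM; compound 3 sits among these without separation, since a 1.2-fold lower number from compound 1 to compound 3 (0.09 log units; within the scatter) and a 1.6-fold higher number from compound 2 to compound 3 (0.20 log units; within the scatter) both fall within the scatter. Compound 4 `COc1ccc(/C=C\C(=O)O)c(OCc2cn(-c3ccc(C#N)cc3)nn2)c1CC=C(C)C` carries cyano in place of hydrogen on an aromatic carbon. Going by the values given here, the nearest precedent is the step from compound 2 to compound 3, which removes a substituent from the same phenyl; read in reverse it bears on adding one there, and it stayed within the scatter. With both precedents this small, no shift beyond the scatter is expected, a 1.2-fold lower number from compound 3 to compound 4 (0.07 log units; within the scatter). For compound 4 the estimated value is 22000 nM, with a range from 9000 nM to 55000 nM.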

Compound 4, half-maximal inhibitory concentration: 21000 nM
For compound 4 the middle estimate is 1.0-fold (0.02 log units) above the measured one; measured number inside the range.
By their numbers in this assay, from the lowest: compounds 2, 4, 3 and 1 (each within the scatter of the next).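

In this assay, cyano para to a large group gives no separation from the unsubstituted phenyl (a 1.2-fold lower number from compound 3 to compound 4 (0.09 log units; within the scatter)), nor does it separate from the larger benzamido at that place (a 1.3-fold higher number from compound 2 to compound 4 (0.11 log units; within the scatter)). Placing 4-cyanophenyl in place of 2-methoxyphenyl on the aromatic nitrogen also stays unresolved (a 1.5-fold lower number from compound 1 to compound 4 (0.19 log units; within the scatter)), so all the aryl changes shown fall within the scatter. No accompanying measurement bears on this result. Going by these compounds, whether an amine or a carboxylic acid at that place would give a step beyond the scatter stays open.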